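The compounds below may be only part of what the source reports. "The series", "measured", "known", "first", "only" and "open" are said of these compounds alone.

Three thiosemicarbazide-type compounds built on a pyridine bearing a methyl group have been measured in a functional assay on MCF7 cells (Homo sapiens) for cytotoxicity, read by MTT assay, with a stated time of 72 h, tested at 100 uM; a lower number here means less inhibition of growth, a higher number more inhibition of growth at the concentration tested. Compound 3 `Cc1ccnc(/C(N)=N/NC(=S)N2CCSCC2)c1` gives 76.8%. Compound 1 `Cc1ccnc(/C(N)=N/NC(=S)N2CCOCC2)c1` differs from compound 3 only in the group attached to the thiocarbonyl carbon, as described by morpholin-4-yl in place of thiomorpholin-4-yl on a thiocarbonyl carbon, and in this assay compound 1 gives 12.8%. That single exchange produced a step of a number 64 percentage points lower from compound 3 to compound 1 (beyond the scatter).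

Compound 2 `Cc1cccc(/C(N)=N/NC(=S)N2CCSCC2)n1` carries the same atoms as compound 3, joined differently; the difference between the two cores is not broken down here. In this assay compound 2 gives 46.8%, which places it between compound 1 and compound 3, beyond the scatter from both.

Compound 4 `Cc1cccc(/C(N)=N/NC(=S)N2CCOCC2)n1` has not yet been measured. It relates to compound 2 as compound 1 relates to compound 3: the difference is morpholin-4-yl in place of thiomorpholin-4-yl on a thiocarbonyl carbon, the same change at the same kind of place. For the measured compounds named here, since the one measured instance of this change, from compound 3 to compound 1, was large, a comparable drop is expected for compound 4 relative to compound 2, though the lower starting point of compound 2 means the number cannot fall as far. The step from compound 2 to compound 4 is therefore estimated at a number 34.8 percentage points lower from compound 2 to compound 4 (beyond the scatter), resting on the step of a number 64 percentage points lower from compound 3 to compound 1 (beyond the scatter). On that basis compound 4 is expected to give about 12% in this assay, likely between 0% and 35%.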

Compound 4, percent growth inhibition at one concentration: 74.7%
Estimate against measurement, compound 4: 62.7 percentage points below; the measured number lies above the stated range.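

The same exchange, morpholin-4-yl in place of thiomorpholin-4-yl on a thiocarbonyl carbon, gave in this assay a step of a number 27.9 percentage points higher from compound 2 to compound 4 (beyond the scatter), so it did not repeat the drop seen on the core of compound 3. The two instances point in opposite directions, so the effect of this change measured on one of these cores could not be carried over to the other: the same change on two cores in this assay, a number 64 percentage points lower (beyond the scatter) from compound 3 to compound 1 and a number 27.9 percentage points higher (beyond the scatter) from compound 2 to compound 4, 91.9 percentage points apart, beyond the scatter of two such steps. This shows that the outcome of the exchange depends on the core that carries it, yet with only two instances it does not show why the cores differ, nor does it establish that either group is the better one in general or give a rule for any further core.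

What the compounds shown leave open is whether the reversal is particular to morpholin-4-yl and thiomorpholin-4-yl, or whether another group on the thiocarbonyl carbon, such as piperidin-1-yl or 4-methylpiperazin-1-yl, would also behave differently on the two cores. They also leave open whether the same reversal would appear across a range of concentrations or in other cell lines, since each compound here has a single reading at one concentration in one cell line.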